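Benzoxazolyl for chlorophenyl on the lactam side chain series

The source may report more compounds than this note shows. Statements on the series, on what has been measured and on what is new or still open speak of the compounds shown alone.

Of the compounds shown here, three with a shared core have been measured. Compound 1 `Cc1cccc(C[C@H](O)/C=C/[C@H]2CCC(=O)N2CCSCCCC(=O)O)c1` gives 5.7 nM in a functional assay on CHO cells for agonist activity at prostaglandin E2 receptor EP4 subtype (Rattus norvegicus), read by cAMP accumulation and immunoassay, with a stated time of 10 min; on this read-out lower numbers stand for an effect already at smaller amounts and higher numbers for an effect only at larger amounts of compound. Among the measured compounds shown here, compound 2 `O=C(O)CCCSCCN1C(=O)CC[C@@H]1/C=C/[C@@H](O)Cc1cccc(OCc2ccncc2)c1` gives 46 nM, and the single one-place step among them, an 8.1-fold higher number from compound 1 to compound 2 (0.91 log units; beyond the scatter), records the change. Compound 3 `O=C(O)c1csc(SCCN2C(=O)CC[C@@H]2/C=C/[C@@H](O)Cc2cccc(-c3ccc(Cl)cc3)c2)n1` gives 27 nM; it holds the second highest of the three numbers, sitting within the scatter of compound 2 and clearly beyond the scatter of compound 1.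

Compound 4 `Cc1cc(C)c2oc(-c3cccc(C[C@H](O)/C=C/[C@H]4CCC(=O)N4CCSc4nc(C(=O)O)cs4)c3)nc2c1` differs from compound 3 by 5,7-dimethyl-1,3-benzoxazol-2-yl in place of 4-chlorophenyl on an aromatic carbon. For the measured compounds named here, no measured step concerns this part of the molecule: the only step available, from compound 1 to compound 2, touches a different substituent on the same ring and gives no direct guide. The group that enters is larger and carries two hydrogen-bond acceptors where none left, so the outcome is uncertain. A step of a 1.5-fold lower number from compound 3 to compound 4 (0.18 log units; within the scatter) is expected for compound 4, without a clear direction beyond the scatter. Compound 4 is estimated at 18 nM, within 5 nM to 65 nM.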

Compound 4, half-maximal effective concentration: 7.7 nM
Estimate against measurement, compound 4: 2.3-fold (0.37 log units) above, and the stated range covers the measured number.
By their numbers in this assay, from the lowest: compounds 1 and 4 (each within the scatter of the next); then compounds 3 and 2 (each within the scatter of the next).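

In this assay, 5,7-dimethyl-1,3-benzoxazol-2-yl in place of 4-chlorophenyl on an aromatic carbon, meta to a large group, gives a 3.5-fold lower number from compound 3 to compound 4 (0.54 log units; beyond the scatter). Among the compounds shown here, this position therefore takes a group with two aromatic rings and hydrogen-bond acceptors, where the group that leaves has none, and the number falls rather than rises, unlike the only earlier step, an 8.1-fold higher number from compound 1 to compound 2 (0.91 log units; beyond the scatter), which concerned a different change on compounds with a different side chain. No measurement at hand accounts for the fall.

The compounds shown do not separate the contribution of the 1,3-benzoxazol-2-yl ring system from that of its two methyl groups, which an unsubstituted benzoxazol-2-yl or a plain phenyl would address. From the compounds shown here alone, whether the step carries over to the open-chain acid side chain of compounds 1 and 2 also remains open.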